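Swapping the bicyclic arm: from compound 3 to compound 4

A few compounds are considered here, and "the series" means these few. Any claim that something is new, unique, unknown or untested is made for them only; others in the source may bear on it.

Compound 3 `CC/C(=C(/c1ccc(/C=C/C(=O)O)cc1)c1ccc2[nH]ncc2n1)c1ccccc1` stands second highest of the three numbers in a functional assay on MCF7 cells (Homo sapiens) for cytotoxicity, read by CellTiter-Glo, with a stated time of 5 days (on this read-out higher numbers stand for weaker inhibition and lower numbers for stronger inhibition), where compound 3 gives 33 nM. Its nearest neighbour is compound 1 `C/C(=C(/c1ccc(/C=C/C(=O)O)cc1)c1ccc2[nH]ncc2c1)c1ccccc1`, which in this assay gives 40 nM; the two lie within the scatter. Compound 2 `O=C(O)/C=C/c1ccc(/C(=C(\c2ccccc2)C(F)(F)F)c2ccc3[nH]ncc3c2)cc1` gives 5.5 nM and sits furthest away, beyond the scatter. Within the data shown here, the only measured step runs from compound 1 to compound 2: a 7.3-fold lower number from compound 1 to compound 2 (0.86 log units; beyond the scatter). Compound 4 `CC/C(=C(/c1ccc(/C=C/C(=O)O)cc1)c1cc2cn[nH]c2cc1F)c1ccccc1` differs from compound 3 by a group of 10 heavy atoms (7 carbon, 2 nitrogen, 1 fluorine; one five-membered aromatic ring with 2 hetero atoms, one six-membered aromatic ring of carbon only) in place of a group of 9 heavy atoms (6 carbon, 3 nitrogen; one five-membered aromatic ring with 2 hetero atoms, one six-membered aromatic ring with 1 hetero atom), on a double-bonded chain carbon bound to an aromatic carbon and a double-bonded chain carbon. Among the measured compounds shown here, no measured step bears on this change, since the one known step concerns trifluoromethyl in place of methyl. It is therefore expected that the step of a 1.1-fold lower number from compound 3 to compound 4 (0.04 log units; within the scatter) stays within the scatter. Compound 4 is estimated at 30 nM, with a range from 12 nM to 80 nM.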

Compound 4, half-maximal inhibitory concentration: 47 nM
Compound 4: the middle estimate sits 1.6-fold (0.19 log units) below what was measured, and the stated range covers the measured number.
By their numbers in this assay, from the lowest: compound 2; then compounds 3, 1 and 4 (each within the scatter of the next).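

In this assay, 6-fluoro-1H-indazol-5-yl on the double-bonded chain carbon gives a 1.4-fold higher number from compound 3 to compound 4 (0.15 log units; within the scatter), so this exchange of the bicyclic arm leaves the number within the scatter. The exchange alters the six-membered ring and adds fluorine in one step, and the two parts cannot be read separately here. Nothing available explains this result.

On these data alone, whether chlorine or a methoxy group in place of the fluorine would also stay within the scatter remains open. So does whether the step from methyl to trifluoromethyl carries over to this arm.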